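From nitrooxy to acetamido: an expected cytotoxicity change

This account rests on a few compounds, and the source may have more. Where it says the series, first, only, none or still open, it means among the compounds named here.

Compound 1 `O=C1/C(=C/c2ccccc2F)CN(S(=O)(=O)c2ccccc2)C/C1=C\c1ccccc1F`: 5700 nM
Compound 2 `O=C1/C(=C/c2cccc(F)c2)CN(S(=O)(=O)c2ccc(O[N+](=O)[O-])cc2)C/C1=C\c1cccc(F)c1`: 15300 nM

For the measured compounds named here, in a functional assay on SMMC-7721 cells (Homo sapiens) for cytotoxicity, read by MTT assay, with a stated time of 24 h (a higher number here means a weaker inhibitor, a lower number a stronger inhibitor), compound 2 gives the higher of the two numbers measured so far, and compound 1 gives the lower; the gap between them lies beyond the usual scatter. Compound 3 `CC(=O)Nc1ccc(S(=O)(=O)N2C/C(=C\c3cccc(F)c3)C(=O)/C(=C/c3cccc(F)c3)C2)cc1` is not yet measured. It differs from compound 2 in one place: acetamido in place of nitrooxy on an aromatic carbon. Going by the values given here, no step between measured compounds covers this change, so its size is unknown. A modest move toward a lower number, or none beyond the scatter, is expected: compound 3 is estimated at 10000 nM, between 4000 nM and 30000 nM, a step of a 1.5-fold lower number from compound 2 to compound 3 (0.18 log units; within the scatter).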

Compound 3, half-maximal inhibitory concentration: 10300 nM
Compound 3: the middle estimate sits 1.0-fold (0.01 log units) below what was measured; measured number inside the range.
By their numbers in this assay, from the lowest: compounds 1, 3 and 2 (each within the scatter of the next, the first and the last beyond it).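

Within this assay the change from nitrooxy to acetamido on an aromatic carbon para to a large group gives a 1.5-fold lower number from compound 2 to compound 3 (0.17 log units; within the scatter) and so stays within the usual scatter. This position therefore accepts a group carrying a hydrogen-bond donor in place of one without a donor, with no change the assay can resolve. Nothing available explains why the two groups read alike.

Going by these compounds, whether an amine or a carboxylic acid on that carbon would read the same remains open. So does the effect of a longer chain there.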